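Series notes: aryl-to-piperidinyl switch on the fused ring

The compounds below may be only part of what the source reports. "The series", "measured", "known", "first", "only" and "open" are said of these compounds alone.

For the measured compounds named here, compound 2 `Cc1cc(-c2c(C)nn(C)c2C)ccc1-c1nnc(N(C)Cc2ccc3ncc(-c4cnn(C)c4)n3c2)o1` holds the lowest of the two numbers measured so far in an assay on COS-7 cells for inhibition of tyrosine-protein kinase receptor TYRO3 (Homo sapiens), read by ELISA, with a stated time of 1 h (a higher number here means a weaker inhibitor, a lower number a stronger inhibitor), giving 12600 nM. Compound 1 `Cc1cc(-c2c(C)nn(C)c2C)ccc1-c1nnc(N(C)Cc2ccc3ncc(-c4ccccc4)n3c2)o1` gives 20000 nM in this assay; the step of a 1.6-fold lower number from compound 1 to compound 2 (0.20 log units; within the scatter) separates the two, so they cannot be ranked against each other.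

Compound 3 `Cc1cc(-c2c(C)nn(C)c2C)ccc1-c1nnc(N(C)Cc2ccc3ncc(C4CCN(C)CC4)n3c2)o1` differs from compound 2 in one place: 1-methylpiperidin-4-yl in place of 1-methyl-1H-pyrazol-4-yl on an aromatic carbon. Going by the values given here, the only measured step, a 1.6-fold lower number from compound 1 to compound 2 (0.20 log units; within the scatter), exchanged one aromatic ring for another at the same carbon and did not move the number beyond the scatter. Among the compounds with values here, that step bears only loosely on the present change, which replaces an aromatic ring with a non-aromatic one, and the data hold no other pair that speaks to such a switch. The numbers therefore give no ground to expect a shift beyond the scatter in this assay in either direction. The estimate is placed close to the measured value, with an expected step of a 1.1-fold lower number from compound 2 to compound 3 (0.02 log units; within the scatter). Compound 3 is expected to give about 12000 nM in this assay, within a range from 4000 nM to 35000 nM.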

Compound 3, half-maximal inhibitory concentration: > 31600 nM
Compound 3 was reported as a limit; the forecaster's own chance of this, stated with the estimate: 15%; middle value at least 2.6-fold (0.42 log units) from the limit.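

In this assay, for the compounds shown here, the earlier swap of one aromatic ring for another at this carbon left no readable difference, whereas the non-aromatic 1-methylpiperidin-4-yl gives an at least 2.5-fold higher number from compound 2 to compound 3 (0.39 log units; beyond the scatter), the first step beyond the scatter and the first sign that this position responds to the group placed on it. Measured against phenyl, the same group gives an at least 1.5-fold higher number from compound 1 to compound 3 (0.19 log units; that floor lies within the scatter), so the floor of that step does not separate compound 3 from compound 1. The value of compound 3 is a limit and not a number, which leaves the full size of both steps unread: the limit of > 31600 nM in this assay, at which 1 of the 3 values shown sits.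

With only one non-aromatic ring at this carbon, the compounds shown do not separate the change from an aromatic to a non-aromatic ring from the effect of the methylated ring nitrogen; cyclohexyl, tetrahydropyran-4-yl or piperidin-4-yl without the methyl would bear on that. Also open, as far as these compounds go, is whether any group at this carbon, such as a small alkyl chain or a primary amide, moves the number beyond the scatter in the lower direction.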